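This account rests on a few compounds, and the source may have more. Where it says the series, first, only, none or still open, it means among the compounds named here.

Compounds measured so far:
- compound 1, `C#Cc1cn([C@@H]2O[C@H](CO)[C@@H](O)[C@H]2O)c2nc(N)nc(OC)c12`: > 20000 nM
- compound 2, `C#Cc1cn([C@@H]2O[C@H](CO)[C@@H](O)[C@H]2O)c2ncnc(OC)c12`: 1730 nM
- compound 3, `CNc1ncnc2c1c(-c1cc3ccccc3o1)cn2[C@@H]1O[C@H](CO)[C@@H](O)[C@H]1O`: > 20000 nM

In a functional assay on HeLa S3 cells (Homo sapiens) for antiproliferative activity, read by XTT assay, with a stated time of 72 h (a higher number here means a weaker inhibitor, a lower number a stronger inhibitor), compound 1 gives > 20000 nM, which is a limit of the assay rather than a measured number. Compound 3 also gives > 20000 nM, again a limit. Among the compounds with values here, only compound 2 returns a measured number, 1730 nM, and the one-place change behind it, an at least 11-fold lower number from compound 1 to compound 2 (1.06 log units; beyond the scatter), is the sole measured step in this set. Compound 1 thus stands among the weaker members shown, and the limit of > 20000 nM in this assay, at which 2 of the 3 values shown sit, marks where it sits.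

The new compound 4, `COc1nc(N)nc2c1c(-c1cc3ccccc3o1)cn2[C@@H]1O[C@H](CO)[C@@H](O)[C@H]1O`, differs from compound 1 in one place: 1-benzofuran-2-yl in place of ethynyl on an aromatic carbon. Within the data shown here, no measured step describes this swap, so nothing here tells how large a move to expect in this assay, or in which direction. The only related fact is that compound 3, which carries the same 1-benzofuran-2-yl group on its own core, sits at the limit as well.

Compound 4 is therefore expected to stay weak, with an estimated step that the limit leaves unreadable from compound 1 to compound 4. The estimate for compound 4 is 40000 nM, in a range from 10000 nM to 200000 nM.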

Compound 4, half-maximal inhibitory concentration: > 20000 nM
Compound 4: no number, only a limit (the forecaster's own chance of this, stated with the estimate: 80%); the middle value is on the limit's open side.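

In this assay compound 4 gives > 20000 nM, which is a limit of the assay and not a number. Compound 1 also sits at a limit, and the step from compound 1 to compound 4 cannot be read. The compounds shown leave open how far either lies beyond that limit, and whether swapping ethynyl for 1-benzofuran-2-yl changes activity at all.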